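From isopropyl to cyclohexyl on a carbonyl carbon

A few compounds are considered here, and "the series" means these few. Any claim that something is new, unique, unknown or untested is made for them only; others in the source may bear on it.

- Compound 1 `CC(C)C(=O)N1N=CCC1c1ccccc1` gives > 1.5 h as a limit
- Compound 2 `O=C(c1cn[nH]c1)N1CCC(C(=O)N2N=CCC2c2ccccc2)CC1` gives > 2.75 h as a limit

In an ADME assay on microsomes (Homo sapiens) for metabolic stability (on this read-out lower numbers stand for a shorter-lived compound and higher numbers for a longer-lived compound), compound 1 stands at > 1.5 h and this is a limit, not a number. Compound 2 gives > 2.75 h as a limit too. Compound 3 `O=C(C1CCCCC1)N1N=CCC1c1ccccc1` has not yet been measured and carries cyclohexyl in place of isopropyl on a carbonyl carbon. Going by the values given here, no measured step shows what this change does, so only a small shortening, close to the usual scatter, is expected in this assay as an at least 1.3-fold lower number from compound 1 to compound 3 (0.13 log units; that floor lies within the scatter) by estimate. For compound 3 the estimate is 1.1 h with an expected range from 0.4 h to 3 h on this read-out.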

Compound 3, half-life: 0.617 h
The estimate for compound 3 lay 1.8-fold (0.25 log units) above the measured number, within the range that was stated.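

In this assay, cyclohexyl in place of isopropyl on a carbonyl carbon gives a change beyond the scatter: an at least 2.4-fold lower number from compound 1 to compound 3 (0.38 log units; beyond the scatter). This position therefore responds to the group it carries, at least for this single swap. The true step may be larger, because compound 1 gives only a limit and not a number: the limit of > 1.5 h in this assay, at which 1 of the 3 values shown sits.

As far as these compounds go, whether the ring or simply the larger number of carbons drives the shift stays open. So does the effect of a methyl group or a ring containing oxygen, such as tetrahydropyranyl, at this place.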